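Swapping methyl for bromo on a cyclohexylphenoxy acid

The source may report more compounds than this note shows. Statements on the series, on what has been measured and on what is new or still open speak of the compounds shown alone.

Measured so far:
Compound 1 `O=C(O)CCCOc1ccc(Cl)cc1C1CCCCC1`: 1990 nM
Compound 2 `Cc1ccc(OCC(=O)O)c(C2CCCCC2)c1`: 353 nM
Compound 3 `CS(=O)(=O)NC(=O)COc1ccc(Cl)cc1C1CCCCC1`: > 10000 nM

In an assay on CHO cells for displacement of a labelled ligand from prostaglandin D2 receptor 2 (Homo sapiens) (a lower number here means a stronger inhibitor, a higher number a weaker inhibitor), compound 2 gives the lowest of the two numbers; the nearest is compound 1. For compound 3 the value is only a limit of the assay (the limit of > 10000 nM in this assay, at which 1 of the 3 values shown sits). Compound 4 `O=C(O)COc1ccc(Br)cc1C1CCCCC1` differs from compound 2 by bromo in place of methyl on an aromatic carbon. Within the data shown here, the single measured step, an at least 5.0-fold higher number from compound 1 to compound 3 (0.70 log units; beyond the scatter), changes the chain, not the aromatic substituent, so no measured step bears directly on this change. With compounds 1 and 3 carrying a halogen there and compound 2 a methyl, compound 4 is expected to give 400 nM, between 150 nM and 1200 nM. The expected step is a 1.1-fold higher number from compound 2 to compound 4 (0.05 log units; within the scatter), within the scatter.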

Compound 4, inhibition constant: 83 nM
Estimate against measurement, compound 4: 4.8-fold (0.68 log units) above; measured number below the stated range.
By their numbers in this assay, from the lowest: compound 4; then compound 2; then compound 1. At a limit, above all of these: compound 3.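

In this assay bromo in place of methyl gives a 4.3-fold lower number from compound 2 to compound 4 (0.63 log units; beyond the scatter) and so shows that what sits on this aromatic carbon, para to a carboxymethoxy group and meta to a cyclohexyl group, matters. Among these compounds, the earlier step changed only the chain, so this is the first measured sign that this substituent alone can move the number beyond the scatter. Nothing given here explains why bromo gives the lower number. From the compounds shown here alone, whether a methoxy group or a nitrile on this carbon would match bromo stays open. So does whether the same swap would act alike on the chain of compound 1.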